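The source may report more compounds than this note shows. Statements on the series, on what has been measured and on what is new or still open speak of the compounds shown alone.

Measured so far in an ADME assay on PANC-1 cells (Homo sapiens) for cytotoxicity, read by sulforhodamine B assay, with a stated time of 48 h, tested at 10 uM; on this read-out lower numbers stand for less inhibition and higher numbers for more inhibition at the one concentration tested (going by the name of the read-out):

compound 1 `COc1nc2ccc(Br)cc2cc1C(c1ccccc1)n1cc(-c2ccccc2)nn1` — in this assay compound 1 gives 30.1%
compound 2 `CCCCCCCCc1cn(C(c2ccccc2)c2cc3cc(Br)ccc3nc2OC)nn1` — in this assay compound 2 gives 12.1%
compound 3 `CCOC(=O)c1cn(C(c2ccccc2)c2cc3cc(Br)ccc3nc2OC)nn1` — in this assay compound 3 gives 15.4%

Compound 3 stands second highest of the three numbers. Its nearest neighbour lies within the scatter, a number 3.3 percentage points higher from compound 2 to compound 3 (within the scatter), while the furthest lies beyond it, a number 14.7 percentage points lower from compound 1 to compound 3 (beyond the scatter). The next compound, compound 4 `COc1nc2ccc(Br)cc2cc1C(c1ccccc1)n1cc(CCO)nn1`, differs from compound 3 in one place: 2-hydroxyethyl in place of ethoxycarbonyl on an aromatic carbon. Among the measured compounds shown here, three measured steps touch the same aromatic carbon. Moving away from phenyl gave modest falls, a number 18 percentage points lower from compound 1 to compound 2 (beyond the scatter) and a number 14.7 percentage points lower from compound 1 to compound 3 (beyond the scatter), whereas the exchange of one non-aromatic group for another stayed flat, a number 3.3 percentage points higher from compound 2 to compound 3 (within the scatter). No measured step introduces a hydroxyl or a hydrogen-bond donor, so the direction of the new change is not shown. Because the swap between two non-phenyl groups gave a number 3.3 percentage points higher from compound 2 to compound 3 (within the scatter), the step from compound 3 to compound 4 is expected to stay within the scatter, a number 1.4 percentage points lower from compound 3 to compound 4 (within the scatter). Compound 4 is therefore estimated at 14%, with a range from 4% to 26%.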

Compound 4, a percentage reported as inhibition, at one concentration (the size of the read-out at that concentration, not a potency): 19.8%
Compound 4: the middle estimate sits 5.8 percentage points below what was measured; the range from low to high includes it.
By their numbers in this assay, from the lowest: compounds 2, 3 and 4 (each within the scatter of the next); then compound 1.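

In this assay, the 2-hydroxyethyl group on this aromatic carbon of the five-membered ring stands with the two other non-phenyl groups, with (a number 4.4 percentage points higher from compound 3 to compound 4 (within the scatter)) against ethoxycarbonyl and (a number 7.7 percentage points higher from compound 2 to compound 4 (within the scatter)) against octyl. Bringing in a hydrogen-bond donor at this position therefore does not set compound 4 apart from compound 2 or compound 3, while phenyl remains distinct, with (a number 10.3 percentage points lower from compound 1 to compound 4 (beyond the scatter)). No measurement given here accounts for this result.

Left open is whether an amine or a carboxylic acid at this aromatic carbon would stay with these three compounds or come closer to compound 1. As far as these compounds go, it is also open whether a benzyl group or a pyridine ring would keep what separates phenyl from the other groups.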